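A few compounds are considered here, and "the series" means these few. Any claim that something is new, unique, unknown or untested is made for them only; others in the source may bear on it.

Three compounds built on one shared core, differing only in the substituted phenyl group at the end of the chain, have been tested in a functional assay on ACHN cells (Homo sapiens); a lower number here means a stronger inhibitor of growth, a higher number a weaker inhibitor of growth. Compound 1 (`O=S(=O)(/C=C/c1ccc(Cl)c(Cl)c1)Cc1ccc(Nc2ncnc3ccccc23)cc1`) gives 28000 nM. Compound 2 (`O=S(=O)(/C=C/c1ccc(Cl)cc1)Cc1ccc(Nc2ncnc3ccccc23)cc1`) gives > 100000 nM, which is a limit of the assay and not a number. Compound 3 (`O=S(=O)(/C=C/c1ccc(F)cc1F)Cc1ccc(Nc2ncnc3ccccc23)cc1`) gives 31000 nM, level with compound 1 within the scatter.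

Compound 4 (`O=S(=O)(/C=C/c1ccc(C(F)(F)F)cc1F)Cc1ccc(Nc2ncnc3ccccc23)cc1`) has trifluoromethyl in place of fluoro on an aromatic carbon, para to a large group and meta to a fluoro group: trifluoromethyl in place of fluoro on an aromatic carbon. The 2,4-difluorophenyl of compound 3 thus becomes 2-fluoro-4-(trifluoromethyl)phenyl.

Within the data shown here, no tested compound carries trifluoromethyl, so the guide is the three steps on this phenyl group. Hydrogen in place of chloro gives an at least 3.5-fold higher number from compound 1 to compound 2 (0.55 log units; beyond the scatter). 2,4-Difluorophenyl in place of 4-chlorophenyl gives an at least 3.2-fold lower number from compound 2 to compound 3 (0.50 log units; beyond the scatter). 2,4-Difluorophenyl in place of 3,4-dichlorophenyl gives a 1.1-fold higher number from compound 1 to compound 3 (0.04 log units; within the scatter). Changes here can therefore matter, in either direction, but the two real numbers sit together, and a drift towards the limit seen for compound 2 remains possible.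

The expected step is a 1.0-fold lower number from compound 3 to compound 4 (0.01 log units; within the scatter), with no change beyond the scatter expected. For compound 4 the estimated value is 30000 nM, with an expected range of 10000 nM to 90000 nM.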

Compound 4, concentration for 50% growth inhibition: 100000 nM
The estimate for compound 4 lay 3.3-fold (0.52 log units) below the measured number; measured number above the stated range.
By their numbers in this assay, from the lowest: compounds 1 and 3 (each within the scatter of the next); then compound 4.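

In this assay, among these compounds, trifluoromethyl in place of fluoro on this aromatic carbon, para to a large group, gives a 3.2-fold higher number from compound 3 to compound 4 (0.51 log units; beyond the scatter) and is the first change on this phenyl group with a size that can be read in full, as the earlier steps beyond the scatter all end at a limit. The 2-fluoro-4-(trifluoromethyl)phenyl group also falls behind the 3,4-dichlorophenyl group, with a 3.6-fold higher number from compound 1 to compound 4 (0.55 log units; beyond the scatter) as the step, whereas the 2,4-difluorophenyl group of compound 3 stays level with it, so the two fluorine-bearing groups are not interchangeable here. 2-Fluoro-4-(trifluoromethyl)phenyl in place of 4-chlorophenyl gives a number no higher from compound 2 to compound 4 (the limit leaves the size open). The size of this step cannot be read, because compound 2 stands at a limit and not at a number: the limit of > 100000 nM in this assay, at which 1 of the 4 values shown sits.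

As far as these compounds go, whether a methyl, a methoxy, a nitrile or an amine in the same place would keep the number of compound 3 or move it further up stays open. Also open, from the compounds shown here alone, is whether any change to this phenyl group can bring the number clearly under those of compound 1 and compound 3.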